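Swapping an ester side chain for a bromophenyl acid

The source may report more compounds than this note shows. Statements on the series, on what has been measured and on what is new or still open speak of the compounds shown alone.

Of the compounds shown here, two have been tested in a functional assay on DU-145 cells (Homo sapiens) for cytotoxicity, read by trypan blue exclusion, with a stated time of 96 h; a lower number here means a stronger inhibitor, a higher number a weaker inhibitor. Compound 1, `COc1ccc(NS(=O)(=O)/C=C/c2ccc(OC)cc2OC)cc1`, gives 15000 nM in this assay. Compound 2, `COC(=O)C(C)Nc1cc(NS(=O)(=O)/C=C/c2c(OC)cc(OC)cc2OC)ccc1OC`, gives 100 nM in this assay, the lower of the two numbers, and its gap to compound 1 lies well beyond the scatter; since the two differ in more than one place, nothing more can be read from that pair. Compound 3, `COc1cc(OC)c(/C=C/S(=O)(=O)Nc2ccc(OC)c(NC(C(=O)O)c3ccc(Br)cc3)c2)c(OC)c1`, is not yet measured. It differs from compound 2 in one place: (4-bromophenyl)(carboxy)methyl in place of 1-(methoxycarbonyl)ethyl on a nitrogen on an aromatic ring. Within the data shown here, there is no measured step of this kind to lean on, so the direction is open. The step is expected to be modest, leaning toward a weaker compound, and the estimated step is a 3.0-fold higher number from compound 2 to compound 3 (0.48 log units; beyond the scatter). Compound 3 is expected to give about 300 nM in this assay, within a range from 50 nM to 3000 nM.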

Compound 3, half-maximal inhibitory concentration: 250 nM
Compound 3: the middle estimate sits 1.2-fold (0.08 log units) above what was measured, within the range that was stated.
By their numbers in this assay, from the lowest: compound 2; then compound 3; then compound 1.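

In this assay, this place on the nitrogen accepts a much larger group at a modest cost: putting (4-bromophenyl)(carboxy)methyl in place of 1-(methoxycarbonyl)ethyl gives a 2.5-fold higher number from compound 2 to compound 3 (0.40 log units; beyond the scatter). The entering group has 11 heavy atoms against 6, and it brings a six-membered aromatic ring and a hydrogen-bond donor that the leaving group lacks, yet the step remains modest. Nothing measured here explains the size or direction of this step.

As far as these compounds go, the aromatic ring, the bromine and the free acid all entered together, so their separate shares in the step remain open. A 1-carboxyethyl group, or a carboxy(phenyl)methyl group without the bromine, on the same nitrogen would help to pull these changes apart.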